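This account rests on a few compounds, and the source may have more. Where it says the series, first, only, none or still open, it means among the compounds named here.

In an assay on cell membranes for displacement of a labelled ligand from corticotropin-releasing factor receptor 1 (Rattus norvegicus) (a lower number here means a stronger inhibitor, a higher number a weaker inhibitor), three compounds have been measured so far. Compound 1 `CCCN(CC1CC1)c1nc(C)nc2c(-c3ccc(OC)nc3C)c(C)nn12` gives 1.6 nM, compound 3 `CCC(CC)Nc1nc(C)nc2c(-c3cnc(OC)cc3C)c(C)nn12` gives 3 nM, and compound 2 `CCN(CC)c1nc(C)nc2c(-c3cnc(OC)cc3C)c(C)nn12` gives 14.5 nM, the highest number of the three. Compound 4 `CCN(CC)c1nc(C)nc2c(-c3cnc(N(C)C)cc3C)c(C)nn12` has not yet been measured; it differs from compound 2 by dimethylamino in place of methoxy on an aromatic carbon. Going by the values given here, the only measured step between close neighbours, a 4.8-fold lower number from compound 2 to compound 3 (0.68 log units; beyond the scatter), concerns the amine on the shared core rather than the group on the six-membered ring with one nitrogen, so no measured step bears directly on this change. A small step with no clear direction beyond the scatter is therefore expected, and a 1.0-fold higher number from compound 2 to compound 4 (0.01 log units; within the scatter) is the estimate. Compound 4 is expected to give 15 nM in this assay, within a range from 5 nM to 50 nM.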

Compound 4, half-maximal inhibitory concentration: 13.8 nM
Estimate against measurement, compound 4: 1.1-fold (0.04 log units) above; the range from low to high includes it.
By their numbers in this assay, from the lowest: compounds 1 and 3 (each within the scatter of the next); then compounds 4 and 2 (each within the scatter of the next).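

Replacing methoxy with dimethylamino next to the ring nitrogen gives a 1.1-fold lower number from compound 2 to compound 4 (0.02 log units; within the scatter) in this assay, so compound 2 and compound 4 cannot be told apart. This position therefore tolerates an oxygen-linked or a nitrogen-linked group, and the one with more heavy atoms, without a change beyond the scatter. Nothing available explains this match.

The compounds shown leave open whether a plain amino group or a larger ring amine such as morpholine would fit as well here. They also leave open whether dimethylamino would behave the same alongside the (pentan-3-yl)amino group of compound 3.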